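Dropping a Methyl Group: From Compound 3 to Compound 4

The compounds below may be only part of what the source reports. "The series", "measured", "known", "first", "only" and "open" are said of these compounds alone.

Of the compounds shown here, three built on a shared core have been tested in an assay on cells with melanin-concentrating hormone receptor 1 (Homo sapiens) as the target, read by radioligand binding; a lower number here means a stronger inhibitor, a higher number a weaker inhibitor. Compound 1, `CC#CCCOc1cccc2ccc(N)nc12`, reaches only the limit of the assay, > 2000 nM, so it gives no number. Compound 2, `Nc1ccc2cccc(OCC3CCOC3)c2n1`, gives 115 nM. Compound 3, `CC1CCCC(Oc2cccc3ccc(N)nc23)C1`, gives 640 nM, the higher of the two numbers, and its gap to compound 2 lies beyond the usual scatter.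

For the measured compounds named here, the only step measured so far, an at least 17-fold lower number from compound 1 to compound 2 (1.24 log units; beyond the scatter), swaps a chain for a ring on the saturated chain carbon bound to an oxygen on the aromatic ring. Compound 4, `Nc1ccc2cccc(OC3CCCCC3)c2n1`, differs from compound 3 in a different way: hydrogen in place of methyl on a saturated ring carbon. Going by the values given here, no measured step trims a methyl from a saturated ring, so that large ring-for-chain step is only a loose guide here. Such a small change is expected to give at most a modest shift, a 1.6-fold lower number from compound 3 to compound 4 (0.20 log units; within the scatter), possibly within the scatter. Compound 4 is therefore estimated at 400 nM, within a range from 150 nM to 1500 nM.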

Compound 4, half-maximal inhibitory concentration: 361 nM
For compound 4 the middle estimate is 1.1-fold (0.04 log units) above the measured one; low and high end bracket the measured number.
By their numbers in this assay, from the lowest: compound 2; then compounds 4 and 3 (each within the scatter of the next). At a limit, above all of these: compound 1.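

In this assay, hydrogen in place of methyl gives a 1.8-fold lower number from compound 3 to compound 4 (0.25 log units; within the scatter), so at this saturated ring carbon, two ring bonds from the ring atom that bears a large group, the methyl makes no difference that can be told from the scatter. Cyclohexyl in place of (oxolan-3-yl)methyl on the oxygen gives a 3.1-fold higher number from compound 2 to compound 4 (0.50 log units; beyond the scatter), and unlike the methyl change, this step lies beyond the scatter. Cyclohexyl in place of pent-3-yn-1-yl gives an at least 5.5-fold lower number from compound 1 to compound 4 (0.74 log units; beyond the scatter), which is a bound and not a measured size, as compound 1 stands at a limit: the limit of > 2000 nM in this assay, at which 1 of the 4 values shown sits.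

The compounds shown leave open whether an amine or a hydroxyl on this same ring carbon would also leave the number unchanged. They also leave open which part of (oxolan-3-yl)methyl accounts for its step.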